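Swapping Nitro for Ethynyl at the Assay Limit

The compounds below may be only part of what the source reports. "The series", "measured", "known", "first", "only" and "open" are said of these compounds alone.

Compound 1 `CN1CCN(c2ccc(Nc3ncc4nc(Nc5ccccc5)n(C5CCCCC5)c4n3)cc2)CC1`: > 5000 nM (a limit)
Compound 2 `CN1CCN(c2ccc(Nc3ncc4nc(Nc5ccccc5)n(-c5ccccc5)c4n3)cc2)CC1`: > 5000 nM (a limit)
Compound 3 `CN1CCN(c2ccc(Nc3ncc4nc(Nc5cccc([N+](=O)[O-])c5)n(C5CCCC5)c4n3)cc2)CC1`: > 5000 nM (a limit)

In a functional assay on HepG2 cells (Homo sapiens) for cytotoxicity, read by MTT assay, with a stated time of 72 h (on this read-out higher numbers stand for weaker inhibition and lower numbers for stronger inhibition), compound 3 gives > 5000 nM, which is a limit and not a number. The whole set rests at the limit of > 5000 nM in this assay, at which 3 of the 3 values shown sit. Compound 4 `C#Cc1cccc(Nc2nc3cnc(Nc4ccc(N5CCN(C)CC5)cc4)nc3n2C2CCCC2)c1` carries ethynyl in place of nitro on an aromatic carbon. Among the compounds with values here, the one measured step, a step that the two limits leave unreadable from compound 1 to compound 2, concerns phenyl in place of cyclohexyl on an aromatic nitrogen, so it gives no size for this change. With no readable step to lean on, what is expected in this assay is a step that the limit leaves unreadable from compound 3 to compound 4, with no clear direction foreseen. Compound 4 is estimated at 6000 nM, with an expected range from 2000 nM to 15000 nM.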

Compound 4, half-maximal inhibitory concentration: 4900 nM
The estimate for compound 4 lay 1.2-fold (0.09 log units) above the measured number; low and high end bracket the measured number.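

In this assay, within the data shown here, compound 4 gives 4900 nM, the first value in the set that is a number and not a limit. Ethynyl in place of nitro on this aromatic carbon gives an at least 1.0-fold lower number from compound 3 to compound 4 (0.00 log units; that floor lies within the scatter), so the change may be small or larger, and its true size stays unknown. The other three compounds all remain at a limit: the limit of > 5000 nM in this assay, at which 3 of the 4 values shown sit.

On these data alone, it remains open whether an amine or a carboxylic acid on this same carbon would move the number beyond the scatter. Also open, as far as these compounds go, is whether ethynyl would still give a readable number with the cyclohexyl of compound 1 on the ring nitrogen.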